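A few compounds are considered here, and "the series" means these few. Any claim that something is new, unique, unknown or untested is made for them only; others in the source may bear on it.

Compound 1 `Fc1cccnc1O/N=C1/C=C(C#Cc2ccccn2)CCC1`: 4.01 nM in an assay on brain (strain Sprague-Dawley) for displacement of a labelled ligand from metabotropic glutamate receptor 5 (Rattus norvegicus), with a stated time of 45 min; on this read-out lower numbers stand for stronger inhibition and higher numbers for weaker inhibition; compound 2 `FCCOCO/N=C1/C=C(C#Cc2ccccn2)CCC1`: 8.41 nM.

For the measured compounds named here, of the two measured compounds, compound 2 gives the higher number in this assay; the only measured step runs a 2.1-fold higher number from compound 1 to compound 2 (0.32 log units; beyond the scatter). Compound 3 `FCCCOCO/N=C1/C=C(C#Cc2ccccn2)CCC1` differs from compound 2 by fluoromethyl in place of fluoro on a saturated chain carbon, two bonds along the chain from an oxygen on a saturated carbon, that is, by one more carbon in the chain. Going by the values given here, no measured step concerns such a lengthening; the step from compound 1 to compound 2 swaps a ring for a chain and says little here. A change beyond the scatter is therefore not expected, and the step from compound 2 to compound 3 is estimated at a 1.0-fold higher number from compound 2 to compound 3 (0.00 log units; within the scatter). Compound 3 is expected to give about 8.5 nM, within 3.5 nM to 22 nM.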

Compound 3, inhibition constant: 5.42 nM
Compound 3: the middle estimate sits 1.6-fold (0.20 log units) above what was measured; the range from low to high includes it.
By their numbers in this assay, from the lowest: compounds 1, 3 and 2 (each within the scatter of the next, the first and the last beyond it).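

Going from 2-fluoroethoxy to 3-fluoropropoxy gives a 1.6-fold lower number from compound 2 to compound 3 (0.19 log units; within the scatter) in this assay, so this chain takes one more carbon with no readable change. The longer chain also gives a 1.4-fold higher number from compound 1 to compound 3 (0.13 log units; within the scatter) even though compound 2 stood beyond the scatter of compound 1. No separate measurement bears on why the numbers fall this way.

From the compounds shown here alone, whether a longer chain such as 4-fluorobutoxy stays in this range remains open, as does the outcome of replacing the terminal fluorine with a hydroxyl or an amine.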